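The compounds below may be only part of what the source reports. "The series", "measured", "known", "first", "only" and "open" are said of these compounds alone.

Working notes on the series. Compound 1 `CCCCCCCCCCCCOC(=O)CCC(=O)N1CCN(CCCOc2cc3c(Nc4ccc(F)c(Cl)c4)ncnc3cc2OC)CC1` and compound 2 `CCCCCCCCCCCCCCCOC(=O)CCC(=O)N1CCN(CCCOc2cc3c(Nc4ccc(F)c(Cl)c4)ncnc3cc2OC)CC1` share one core and differ only at the end of the ester chain. In a functional assay on A549 cells (Homo sapiens) for cytotoxicity, read by MTT assay, with a stated time of 24 h, tested at 20 uM (a higher number here means a weaker effect of the compound at the concentration tested, a lower number a stronger effect), compound 1 gives 86.8%, and compound 2 gives 91.2%; the two values lie within the scatter of each other, as the step of a number 4.4 percentage points higher from compound 1 to compound 2 (within the scatter) shows. Compound 3 `CCCCCCCCCCCCCCCCCCOC(=O)CCC(=O)N1CCN(CCCOc2cc3c(Nc4ccc(F)c(Cl)c4)ncnc3cc2OC)CC1` extends the same chain again: propyl in place of hydrogen on a saturated chain carbon, ten or more bonds along the chain from an oxygen next to a carbonyl group. Among the compounds with values here, the only step that bears on it is the one from compound 1 to compound 2, which stayed within the scatter, so no step beyond the scatter is expected in this assay. Compound 3 is therefore expected to give about 92%, between 80% and 102%, an expected step of a number 0.8 percentage points higher from compound 2 to compound 3 (within the scatter).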

Compound 3, a percentage reported as activity, at one concentration (the size of the read-out at that concentration, not a potency): 90.5%
The estimate for compound 3 lay 1.5 percentage points above the measured number, and the stated range covers the measured number.
By their numbers in this assay, from the lowest: compounds 1, 3 and 2 (each within the scatter of the next).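

In this assay the further propyl gives a number 0.7 percentage points lower from compound 2 to compound 3 (within the scatter) and hexyl in place of hydrogen gives a number 3.7 percentage points higher from compound 1 to compound 3 (within the scatter) at this saturated chain carbon. The earlier pair covered propyl alone; the read-out now also stays within the scatter across the longer hexyl change. No measured evidence bears on this result.

From the compounds shown here alone, whether a much longer chain would leave the read-out within the scatter stays open. So does the effect of an amine or a carboxylic acid at the end of the ester chain.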